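Notes on a double-bond isomer pair

The source may report more compounds than this note shows. Statements on the series, on what has been measured and on what is new or still open speak of the compounds shown alone.

Measured so far in a functional assay on K562/Adr cells (Homo sapiens) for cytotoxicity, read by sulforhodamine B assay, with a stated time of 48 h; on this read-out higher numbers stand for weaker inhibition and lower numbers for stronger inhibition:
- compound 1 `CCN(CC)CCCn1c(=O)/c(=C/c2cc(OC)c(OC)c(OC)c2)s/c1=C1/C(=O)Nc2ccc(C)cc21` gives 2020 nM
- compound 2 `CCN(CC)CCCn1c(=O)/c(=C/c2cc(OC)c(OC)c(OC)c2)s/c1=C1/C(=O)Nc2ccc(Cl)cc21` gives 1650 nM
- compound 3 `CCN(CC)CCCn1c(=O)/c(=C/c2ccc(F)c(F)c2)s/c1=C1/C(=O)Nc2ccc(F)cc21` gives 6480 nM

Compound 3 has the highest of the three numbers and lies beyond the scatter of both others. the two compounds have the same atoms and bonds and differ only in configuration as drawn: 1 of 2 stereo elements differ; a double bond is drawn E in compound 3 and Z in compound 4 is the whole change from compound 3 to compound 4 `CCN(CC)CCCn1c(=O)/c(=C/c2ccc(F)c(F)c2)s/c1=C1\C(=O)Nc2ccc(F)cc21` and no atoms or bonds differ. Going by the values given here, no measured step concerns configuration. The only one, a 1.2-fold lower number from compound 1 to compound 2 (0.09 log units; within the scatter) for chloro in place of methyl on an aromatic carbon, lies within the scatter and offers weak guidance. No step beyond the scatter is therefore expected in this assay and no direction can be favoured. The estimate means a 1.2-fold lower number from compound 3 to compound 4 (0.07 log units; within the scatter) as the expected step. The estimate for compound 4 is 5500 nM with 2000 nM to 15000 nM as the expected range.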

Compound 4, half-maximal inhibitory concentration: 6480 nM
Beside the measured number, compound 4's estimate is 1.2-fold (0.07 log units) below it; the range from low to high includes it.
By their numbers in this assay, from the lowest: compounds 2 and 1 (each within the scatter of the next); then compounds 3 and 4 (each within the scatter of the next).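

In this assay, going by these compounds alone, the first measured step on configuration shows no change at the digits printed from compound 3 to compound 4 (within the scatter). For this pair, the double bond drawn E or Z makes no readable difference, and the comparison isolates that one element: the fact that compounds 3 and 4 differ only in the configuration as drawn. The result holds for this pair only and gives no direction for configuration elsewhere in the series.

On these data alone, whether compounds 1 and 2 would behave alike under the same change stays open. So does the outcome of this change with a morpholine or a carboxylic acid in place of the diethylamine.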